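Compound 3 to compound 4: an aryl exchange, cytotoxicity notes

This account rests on a few compounds, and the source may have more. Where it says the series, first, only, none or still open, it means among the compounds named here.

In a functional assay on MCF7 cells (Homo sapiens) for cytotoxicity, read by sulforhodamine B assay, with a stated time of 48 h (a higher number here means a weaker inhibitor, a lower number a stronger inhibitor), compound 3 `COc1ccc(-c2cc(C(=O)/C=C/c3cc(OC)c(OC)c(OC)c3)ccc2N)cc1OC` gives 6580 nM, the lower of the two numbers available, and its gap to compound 2 `COc1cc(/C=C/C(=O)c2cccc(-c3cccc(F)c3)c2)ccc1O`, at 14200 nM, lies beyond the scatter. Compound 1 `COc1ccc(/C=C/C(=O)c2ccc(N)c(-c3ccc(F)cc3)c2)cc1O` adds no number, as its entry reads "not determined" (no result reported).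

Compound 4 `COc1cc(/C=C/C(=O)c2ccc(N)c(-c3ccc(F)cc3)c2)cc(OC)c1OC` differs from compound 3 in one place: 4-fluorophenyl in place of 3,4-dimethoxyphenyl on an aromatic carbon. In words, 4-fluorophenyl stands in place of 3,4-dimethoxyphenyl on an aromatic carbon, ortho to an amino group and meta to a large group.

Among the compounds with values here, no measured pair differs in one place only, so no measured step is available as a guide to size. Compound 1 carries the same 4-fluorophenyl as compound 4, but it offers no value to lean on. Compound 2 also holds a fluorine and gives 14200 nM, yet it differs from compound 3 in more than one place, which makes it only a loose guide. The estimated step of a 1.2-fold higher number from compound 3 to compound 4 (0.08 log units; within the scatter) is expected to stay within the scatter, leaning slightly towards a higher number. For compound 4 the expected value is 8000 nM, with an estimated range from 2500 nM to 25000 nM.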

Compound 4, half-maximal inhibitory concentration: 9030 nM
The estimate for compound 4 lay 1.1-fold (0.05 log units) below the measured number, and the stated range covers the measured number.
By their numbers in this assay, from the lowest: compounds 3, 4 and 2 (each within the scatter of the next, the first and the last beyond it).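

In this assay, within the data shown here, the step of a 1.4-fold higher number from compound 3 to compound 4 (0.14 log units; within the scatter) is the first one-place comparison, and it concerns the aromatic carbon ortho to an amino group and meta to a large group. With the rest of the structure held constant, 4-fluorophenyl and 3,4-dimethoxyphenyl cannot be told apart at this position, even though the group that leaves carries hydrogen-bond acceptors and the group that enters carries none. Cytotoxicity at this level therefore does not depend on the methoxy groups of this aryl ring, at least for this one exchange, and nothing at hand bears on why the two aryl groups read alike.

Still open, from the compounds shown here alone, is whether any group at this position can move the number beyond the scatter, for example a 4-trifluoromethylphenyl ring, a pyridine ring or a carboxylic acid on the aryl ring. The compounds shown also leave open whether the same exchange would read alike on a different core, or whether replacing the amino group itself with an amide would change what this position tolerates.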